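The source may report more compounds than this note shows. Statements on the series, on what has been measured and on what is new or still open speak of the compounds shown alone.

In a functional assay on MCF7 cells (Homo sapiens) for antiproliferative activity, read by MTT assay, with a stated time of 48 h (on this read-out higher numbers stand for weaker inhibition and lower numbers for stronger inhibition), compound 2 `O=Cc1ccc(C2=C(c3ccccc3)C3(C=CC(=O)C=C3)OC2=O)s1` gives 6230 nM, and compound 1 `COc1ccc(C2=C(c3ccccc3)C3(C=CC(=O)C=C3)OC2=O)cc1` gives 5860 nM; the two numbers lie within the scatter of each other, as the step of a 1.1-fold higher number from compound 1 to compound 2 (0.03 log units; within the scatter) shows. Compound 3 `O=C1C=CC2(C=C1)OC(=O)C=C2c1ccccc1` differs from compound 2 by hydrogen in place of 5-formylthiophen-2-yl on a double-bonded ring carbon. Among the compounds with values here, the only measured step, a 1.1-fold higher number from compound 1 to compound 2 (0.03 log units; within the scatter), exchanged one aryl group for another rather than removing it, so no measured step bears directly on this change and its direction is uncertain. Compound 3 is expected to give a somewhat higher number, a step of a 1.4-fold higher number from compound 2 to compound 3 (0.16 log units; within the scatter). Compound 3 is estimated at 9000 nM in this assay, between 3000 nM and 30000 nM.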

Compound 3, half-maximal inhibitory concentration: 6460 nM
Compound 3: the middle estimate sits 1.4-fold (0.14 log units) above what was measured; low and high end bracket the measured number.
By their numbers in this assay, from the lowest: compounds 1, 2 and 3 (each within the scatter of the next).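

In this assay, the aryl group on the double-bonded ring carbon can be removed altogether without a change beyond the scatter: hydrogen in place of 5-formylthiophen-2-yl gives (a 1.0-fold higher number from compound 2 to compound 3 (0.02 log units; within the scatter)) and hydrogen in place of 4-methoxyphenyl gives (a 1.1-fold higher number from compound 1 to compound 3 (0.04 log units; within the scatter)). Within the data shown here, the earlier pair showed only one aryl group exchanged for another, whereas these steps show that neither group is needed to keep the number in this range. Nothing available explains this result. From the compounds shown here alone, whether an amine, a carboxylic acid or a longer chain on this carbon would shift the number remains open, as does the role of the phenyl group that all three compounds retain.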